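Nitro in Place of Hydrogen on the Aryl Ring

The compounds below may be only part of what the source reports. "The series", "measured", "known", "first", "only" and "open" are said of these compounds alone.

Within the data shown here, only two compounds have been measured in an assay on isolated protein for inhibition of Death-associated protein kinase 3 (Homo sapiens), tested at 10 uM (a higher number here means a stronger effect of the compound at the concentration tested, a lower number a weaker effect), and their numbers lie within the scatter of each other: compound 2 `O=C1OC(c2ccccc2)=N/C1=C\c1ccncc1` gives 1%, and compound 1 `O=C1OC(c2cccc(Br)c2)=N/C1=C\c1ccncc1` gives 0%. Among the measured compounds shown here, the single measured step, a number 1 percentage points higher from compound 1 to compound 2 (within the scatter), is within the scatter. Compound 3 `O=C1OC(c2cccc([N+](=O)[O-])c2)=N/C1=C\c1ccncc1` differs from compound 2 by nitro in place of hydrogen on an aromatic carbon. For the measured compounds named here, no measured step involves a nitro group, so the one step known bears on this change only loosely; with both measured values near zero, no step beyond the scatter is expected, a number 1 percentage points higher from compound 2 to compound 3 (within the scatter). Compound 3 is therefore estimated at 2%, between 0% and 15%.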

Compound 3, a percentage reported as inhibition, at one concentration (the size of the read-out at that concentration, not a potency): 0%
Estimate against measurement, compound 3: 2 percentage points above; the measured number falls inside the stated range.
By their numbers in this assay, from the lowest: compounds 1, 3 and 2 (each within the scatter of the next).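

With nitro, a third group has now been read at this place on the aromatic ring, meta to a large group, and in this assay it gives no difference beyond the scatter from either hydrogen (a number 1 percentage points lower from compound 2 to compound 3 (within the scatter)) or bromo (no change at the digits printed from compound 1 to compound 3 (within the scatter)). Hydrogen, bromo and nitro at this position therefore cannot be told apart in this assay. No evidence is available to explain this result. Open, going by these compounds, is whether an amine, a carboxylic acid or a longer chain at this place would give a number beyond the scatter, and whether a change elsewhere on the shared core would do so.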